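The source may hold more compounds than are shown below. What is called first, only, known or untested is meant among the compounds shown, and "the series" means these compounds.

Among the compounds with values here, only two compounds have numbers so far. In a functional assay on MCF7 cells (Homo sapiens) for inhibition, read by colorimetric assay and MTT assay, with a stated time of 72 h (on this read-out lower numbers stand for stronger inhibition and higher numbers for weaker inhibition), compound 1 `Cn1c2cnc1OCCCCCCCCCCOc1cc3ccccc3cc1-2` gives 24000 nM, and compound 2 `C=CCCCCOc1ccccc1-c1cnc(OCCCC=C)n1C` gives 7000 nM. Compound 2 therefore holds the lower of the two numbers, which means the stronger inhibition of this pair, and the gap between them lies beyond the usual scatter of repeated measurements.

The next compound, compound 3 `C=CCCCCOc1ccccc1-c1cnc(OC)n1C`, differs from compound 2 in one place: hydrogen in place of but-3-en-1-yl on a saturated chain carbon bound to an oxygen on an aromatic ring. In words, hydrogen stands in place of but-3-en-1-yl on a saturated chain carbon bound to an oxygen on an aromatic ring. Cut one bond further out, the same difference reads pent-4-en-1-yl to methyl.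

Within the data shown here, no pair of measured compounds shows this change on its own, so the data offer no direct guide to its size. A moderate move towards weaker inhibition in this assay is expected, with a result inside the scatter still possible. Put as a number, the expected change is the estimated step of a 2.0-fold higher number from compound 2 to compound 3 (0.30 log units; within the scatter). Compound 3 is estimated at 14000 nM, with an expected range of 5000 nM to 40000 nM.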

Compound 3, half-maximal inhibitory concentration: 98000 nM
Compound 3: middle estimate off by 7.0-fold (0.85 log units), on the low side, and the stated range ends below it.
By their numbers in this assay, from the lowest: compound 2; then compound 1; then compound 3.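

Shortening the pent-4-en-1-yl group on this oxygen to methyl in this assay gives a 14-fold higher number from compound 2 to compound 3 (1.15 log units; beyond the scatter), a large step that lies beyond the scatter. This position, on a saturated chain carbon bound to an oxygen on an aromatic ring, is therefore sensitive to change, and in this pair the longer chain goes with the stronger inhibition. Within the data shown here, the group that leaves is made only of carbon and hydrogen, with 4 heavy atoms, 1 double bond, no hydrogen-bond donors or acceptors and no net charge, and nothing available here explains why its loss moves the number so far.

With only pent-4-en-1-yl and methyl shown at this position, it stays open whether the step follows the length of the chain or its double bond, a question that a saturated pentyl chain would help to separate. Going by these compounds, it also stays open how an ethyl group, a longer chain or a chain ending in an amine would fit between or beyond these two compounds.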